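Ester Cleavage in a Triazole Series Tested on Colon Cells

This account rests on a few compounds, and the source may have more. Where it says the series, first, only, none or still open, it means among the compounds named here.

Three compounds were measured in a functional assay on HCT-116 cells (Homo sapiens) for inhibition, read by MTT assay, with a stated time of 2 days, tested at 10 uM; on this read-out higher numbers stand for more inhibition at the one concentration tested (going by the name of the read-out) and lower numbers for less inhibition. Compound 1 `O=C(OCCCc1ccccc1)c1cc(-n2cc(-c3cccc(O)c3)nn2)ccc1O` gives 11%. Compound 2 `COc1ccccc1-c1cn(-c2ccc(O)c(C(=O)OCCCc3ccccc3)c2)nn1` gives 7%, and compound 3 `O=C(O)c1cc(-n2cc(-c3cccc(O)c3)nn2)ccc1O` gives 5% in this assay. Compound 2 is set apart from compound 1 by 2-methoxyphenyl in place of 3-hydroxyphenyl on an aromatic carbon, and this goes with a number 4 percentage points lower from compound 1 to compound 2 (within the scatter). Compound 3 is set apart from compound 1 by hydrogen in place of 3-phenylpropyl on an oxygen next to a carbonyl group, and this goes with a number 6 percentage points lower from compound 1 to compound 3 (within the scatter). All three numbers lie within the scatter of one another, so no order among them can be claimed.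

Compound 4 `COc1ccccc1-c1cn(-c2ccc(O)c(C(=O)O)c2)nn1` has not been measured. It differs from compound 2 by hydrogen in place of 3-phenylpropyl on an oxygen next to a carbonyl group. This is the same change as from compound 1 to compound 3, made at the same place; the cores of the two pairs differ by 2-methoxyphenyl in place of 3-hydroxyphenyl on an aromatic carbon. The step from compound 2 to compound 4 is expected to be a number 3 percentage points lower from compound 2 to compound 4 (within the scatter), which rests on compound 3 and its step of a number 6 percentage points lower from compound 1 to compound 3 (within the scatter), a small move within the scatter. Compound 4 is therefore estimated to give 4% in this assay, expected to fall between -5% and 12%.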

Compound 4, a percentage reported as inhibition, at one concentration (the size of the read-out at that concentration, not a potency): 4%
Compound 4: the middle estimate sits on the measured number at the digits printed, and the stated range covers the measured number.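

In this assay, hydrogen in place of 3-phenylpropyl on an oxygen next to a carbonyl group goes with a number 3 percentage points lower from compound 2 to compound 4 (within the scatter). Set beside the earlier step, the change reads alike on the two cores: the same change on two cores in this assay, a number 6 percentage points lower (within the scatter) from compound 1 to compound 3 and a number 3 percentage points lower (within the scatter) from compound 2 to compound 4, 3 percentage points apart, within the scatter of two such steps. This shows no detectable dependence on the core between 2-methoxyphenyl and 3-hydroxyphenyl, but since each step lies within the scatter, it does not show that the change has any effect on either core, nor that the two steps are truly the same size.

The compounds shown hold only the 3-phenylpropyl ester or the free carboxylic acid at this place, so what an amide, a methyl ester or a chain longer than 3-phenylpropyl would give there stays open. Also open, on these data alone, is whether the step would read the same on a core carrying an aminophenyl group in place of 3-hydroxyphenyl or 2-methoxyphenyl.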